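Replacing the bromophenyl group of compound 1 with a methoxyphenyl

The source may hold more compounds than are shown below. What is called first, only, known or untested is meant among the compounds shown, and "the series" means these compounds.

Within the data shown here, compound 1 `COc1cc(C(=O)c2sc(-c3ccc(Br)cc3)cc2N)cc(OC)c1OC` gives the highest number of the three compounds measured so far in a functional assay on CCRF-CEM cells (Homo sapiens) for antiproliferative activity (on this read-out lower numbers stand for stronger inhibition and higher numbers for weaker inhibition), where compound 1 gives 86 nM. Compound 2 `COc1cc(C(=O)c2sc(-c3cccc([N+](=O)[O-])c3)cc2N)cc(OC)c1OC` gives 5.9 nM in this assay, and compound 3 `COc1cc(C(=O)c2sc(-c3ccccc3Cl)cc2N)cc(OC)c1OC` gives 16 nM in the same assay. Both changes away from the 4-bromophenyl of compound 1 lowered the number: a 15-fold lower number from compound 1 to compound 2 (1.16 log units; beyond the scatter) and a 5.4-fold lower number from compound 1 to compound 3 (0.73 log units; beyond the scatter); between the two replacements, a 2.7-fold higher number from compound 2 to compound 3 (0.43 log units; beyond the scatter).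

Compound 4 `COc1cccc(-c2cc(N)c(C(=O)c3cc(OC)c(OC)c(OC)c3)s2)c1` carries a different change at the same place: 3-methoxyphenyl in place of 4-bromophenyl on an aromatic carbon. The two measured steps that start from compound 1 both bear on it, one large and one modest, and both in the same direction, so a lower number than that of compound 1 is expected here too, most likely of a size between those two steps. Compound 4 is therefore estimated at 20 nM in this assay, with a range from 5 nM to 80 nM. This estimate means a step of a 4.3-fold lower number from compound 1 to compound 4 (0.63 log units; beyond the scatter).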

Compound 4, half-maximal inhibitory concentration: 16 nM
For compound 4 the middle estimate is 1.3-fold (0.10 log units) above the measured one, and the stated range covers the measured number.
By their numbers in this assay, from the lowest: compound 2; then compounds 3 and 4 (each within the scatter of the next); then compound 1.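

In this assay the 3-methoxyphenyl group gives a 5.4-fold lower number from compound 1 to compound 4 (0.73 log units; beyond the scatter) and is the third replacement of the 4-bromophenyl at this place to lower the number, so all the replacements shown go the same way. With no change at the digits printed from compound 3 to compound 4 (within the scatter) as the reading, the 3-methoxyphenyl and 2-chlorophenyl groups stand level here, even though they differ in both substituent and its place on the phenyl. Among these compounds, the reading of a 2.7-fold higher number from compound 2 to compound 4 (0.43 log units; beyond the scatter) adds the first comparison with the place on the phenyl held constant, and it shows that methoxy and nitro are not equivalent at that place.

The data shown offer no measured basis for explaining these differences. Going by these compounds, it remains open whether the higher number of compound 1 belongs to the bromine or to its place on the phenyl, and how a 3-aminophenyl or 4-methoxyphenyl group would read here.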